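A few compounds are considered here, and "the series" means these few. Any claim that something is new, unique, unknown or untested is made for them only; others in the source may bear on it.

Compound 1 `CC(C)(C)NCc1cc(Cl)cc(Nc2nc3cc(F)c(F)cc3n2Cc2ccc(C(F)(F)F)cc2)c1O`: 89%
Compound 2 `CCNCc1cc(C)cc(Nc2nc3ccccc3n2Cc2ccc(C(F)(F)F)cc2)c1O`: 98%
Compound 3 `CCNCc1cc(Cl)cc(Nc2nc3ccccc3n2Cc2ccc(C(F)(F)F)cc2)c1O`: 94%

In an ADME assay on microsomes from liver (Homo sapiens) for metabolic stability, read by LC-MS, with a stated time of 30 min, tested at 1 uM (a higher number here means that more of the compound is left, a lower number that less of the compound is left), compound 2 gives 98%, and the other two compounds lie within the scatter of it. Compound 4 `CCN(CC)Cc1cc(C)cc(Nc2nc3ccccc3n2Cc2ccc(C(F)(F)F)cc2)c1O` differs from compound 2 by ethyl in place of hydrogen on an amine nitrogen, which turns ethylamino into diethylamino. Going by the values given here, the one measured single-place step, a number 4 percentage points lower from compound 2 to compound 3 (within the scatter), is chloro in place of methyl on an aromatic carbon, so it bears only indirectly on this change. Among the compounds with values here, no measured step alters the amine nitrogen alone. Compound 1, with a different amine group and other changes, still gives 89%. A slightly lower number is therefore expected, within the scatter, and the estimated step is a number 7 percentage points lower from compound 2 to compound 4 (within the scatter). For compound 4 the expected value is 91%, with an estimated range of 76% to 100%.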

Compound 4, percent of the compound remaining: 36%
Estimate against measurement, compound 4: 55 percentage points above; the whole stated range lies above it.
By their numbers in this assay, from the lowest: compound 4; then compounds 1, 3 and 2 (each within the scatter of the next).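

In this assay ethyl in place of hydrogen on an amine nitrogen brings a number 62 percentage points lower from compound 2 to compound 4 (beyond the scatter) and marks this nitrogen as a place where one small addition changes the read-out far beyond the scatter. The earlier step on the aromatic carbon, a number 4 percentage points lower from compound 2 to compound 3 (within the scatter) and gave no such sign. No measurement shown bears on the reason for this fall. On these data alone, whether a longer chain such as propyl, or a ring amine such as pyrrolidine, on this nitrogen reads closer to compound 2 or compound 4 stays open. So does whether the step holds with chloro in place of methyl.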